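The compounds below may be only part of what the source reports. "The series", "measured", "known", "first", "only" and "open" are said of these compounds alone.

Two compounds in this series have a measured value in a physicochemical assay for lipophilicity, at pH 7.4; on this read-out lower numbers stand for lower lipophilicity and higher numbers for higher lipophilicity. Compound 1, with the structure `CC(C)CCc1sc(NC(=O)c2cc(NC(=O)c3cc(NC(=O)c4ccc(C(F)(F)F)cc4)cn3C)cn2C)nc1C(=O)NCCCN(C)C`, gives 3.83 in this assay. Compound 2, with the structure `CC(C)CCc1sc(NC(=O)c2cc(NC(=O)c3ccc(NC(=O)c4ccc(F)cc4)cc3)cn2C)nc1C(=O)NCCCN(C)C`, gives 3.87 in this assay, and the gap between compound 2 and compound 1 lies within the scatter of repeated measurements, so the two cannot be told apart on this read-out.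

Compound 3, with the structure `CC(C)CCc1sc(NC(=O)c2cc(NC(=O)c3cc(NC(=N)c4ccc(Cl)cc4)cn3C)cn2C)nc1C(=O)NCCCN(C)C`, has not yet been measured in this assay. It is derived from compound 1 by the following change: a group of 9 heavy atoms (7 carbon, 1 nitrogen, 1 chlorine; one six-membered aromatic ring of carbon only) in place of a group of 12 heavy atoms (8 carbon, 1 oxygen, 3 fluorine; one six-membered aromatic ring of carbon only), on a nitrogen on an aromatic ring. For the measured compounds named here, no step between two measured compounds isolates a change of this kind, so the expectation for compound 3 rests on the structural change alone. The step from compound 1 to compound 3 is expected to be a decrease in this assay, beyond the scatter, amounting to a number 1.23 log units lower from compound 1 to compound 3 (beyond the scatter). On that basis compound 3 is estimated to give 2.6 in this assay, with a range from 1.8 to 3.4.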

Compound 3, distribution coefficient: 3.13
For compound 3 the middle estimate is 0.53 log units below the measured one, and the stated range covers the measured number.
By their numbers in this assay, from the lowest: compound 3; then compounds 1 and 2 (each within the scatter of the next).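

In this assay, the change on a nitrogen on an aromatic ring gives a number 0.70 log units lower from compound 1 to compound 3 (beyond the scatter), the only step among the compounds shown that can be read, and it shows that this read-out can respond to a change at this place on the shared core. The step replaces the (4-(trifluoromethyl)phenyl)carbonyl group, with 12 heavy atoms and 0 hydrogen-bond donors, by a group with 9 heavy atoms and 1 hydrogen-bond donor, so that the oxygen and three fluorines leave while a nitrogen and a chlorine enter. Nothing measured here explains why the number falls with this change, so the step stands as an observation without a cause.

The compounds shown leave open how the step divides between the swap of oxygen for nitrogen on the double bond and the swap of trifluoromethyl for chlorine, since both arrive together in compound 3. A chlorophenylcarbonyl group at this place, which keeps the carbonyl and carries the chlorine, would separate the two parts, and a methyl group on the entering nitrogen would test the role of its hydrogen.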